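Little Cytotoxicity Across Three Measured Compounds

This account rests on a few compounds, and the source may have more. Where it says the series, first, only, none or still open, it means among the compounds named here.

Values in an ADME assay on BCBL1 cells (Homo sapiens) for cytotoxicity, with a stated time of 7 days (a lower number here means that less compound is tolerated, a higher number that more compound is tolerated), for the measured compounds:
Compound 1 `COCCOc1nc(N)nc2c1ncn2/C=C1/CC1(CO)CO` gives > 20000 nM as a limit
Compound 2 `Nc1nc(NC2CC2)c2ncn(/C=C3/CC3(CO)CO)c2n1` gives 71500 nM as a number
Compound 3 `Nc1nc(NC2CCCCC2)c2ncn(/C=C3/CC3(CO)CO)c2n1` gives > 20000 nM as a limit

As far as these compounds go, compound 3 stands at > 20000 nM as a limit and not a number, so its exact place on the scale is unknown. Compound 4 `Nc1nc(SC2CCCC2)c2ncn(/C=C3/CC3(CO)CO)c2n1` carries cyclopentylsulfanyl in place of cyclohexylamino on an aromatic carbon, and cyclopentylsulfanyl in place of cyclohexylamino on an aromatic carbon gives the full count of that change. For the measured compounds named here, three measured steps bear on it: a step that the limit leaves unreadable from compound 1 to compound 2 and a step that the two limits leave unreadable from compound 1 to compound 3 and a step that the limit leaves unreadable from compound 2 to compound 3 all involve a change of group on the shared core, yet none has a readable size. The picture is dominated by the limit of > 20000 nM in this assay, at which 2 of the 3 values shown sit, and offers no measured size for a change of this kind. Going by the values given here, compound 2 with 71500 nM is the only true number in the set. Among the compounds with values here, no step of a known size is therefore expected in this assay and no direction can be given. The expected move is a step that the limit leaves unreadable from compound 3 to compound 4 on this estimate. Compound 4 is estimated at 40000 nM with an expected range from 12000 nM to 100000 nM.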

Compound 4, half-maximal cytotoxic concentration: > 20000 nM
Compound 4: only a limit was reported; the forecaster's own chance of this, stated with the estimate: 65%; the middle value does not contradict the limit.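

In this assay compound 4 gives > 20000 nM, which is a limit and not a number. For the compounds shown here, no step between compound 4 and compound 1, compound 2 or compound 3 can be read, so cyclopentylsulfanyl has no measured effect here. The compounds shown leave open whether any change of group on this aromatic carbon shifts the tolerated concentration.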